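The source may report more compounds than this note shows. Statements on the series, on what has been measured and on what is new or still open speak of the compounds shown alone.

Working notes on the series. In a functional assay on the whole organism (Gastrocnemius, strain Sprague-Dawley) for inhibition, with Rattus norvegicus as the target (on this read-out higher numbers stand for an effect only at larger amounts of compound and lower numbers for an effect already at smaller amounts), compound 1 `O=C1NC(=O)N(/N=C/c2ccc(-c3ccc(Cl)c(Cl)c3)o2)C1O` gives 0.019 umol/kg, compound 2 `O=C1NC(=O)N(/N=C/c2ccc(-c3ccc(Cl)cc3)o2)C1O` gives 0.016 umol/kg and compound 3 `N#Cc1ccc(-c2ccc(/C=N/N3C(=O)NC(=O)C3O)o2)cc1` gives 0.025 umol/kg in the same read-out. Compound 2 stands within the scatter of both compound 1 and compound 3, so its number shows no clear separation from either.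

The next change leads from compound 2 to compound 4 `Nc1ccc(-c2ccc(/C=N/N3C(=O)NC(=O)C3O)o2)cc1`, with amino in place of chloro on an aromatic carbon, 4-chlorophenyl becoming 4-aminophenyl (amino in place of chloro on an aromatic carbon). For the measured compounds named here, two measured steps bear on this change, as each also replaces chloro on an aromatic carbon. Going by the values given here, no compound with amino has been measured yet, so these two steps are the only guide to its size. Since a 1.2-fold lower number from compound 1 to compound 2 (0.07 log units; within the scatter), with hydrogen in place of chloro, and a 1.6-fold higher number from compound 2 to compound 3 (0.19 log units; within the scatter), with cyano in place of chloro, both stay within the scatter, no step beyond the scatter is expected in this assay, and the data leave the direction open. The estimated step is a 1.4-fold higher number from compound 2 to compound 4 (0.14 log units; within the scatter), which would be a small one. For compound 4 the expected value is 0.022 umol/kg, with an estimated range from 0.008 umol/kg to 0.06 umol/kg in the same read-out.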

Compound 4, dose for half-maximal effect: 0.039 umol/kg
Estimate against measurement, compound 4: 1.8-fold (0.25 log units) below; measured number inside the range.
By their numbers in this assay, from the lowest: compounds 2, 1, 3 and 4 (each within the scatter of the next, the first and the last beyond it).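

In this assay, for the compounds shown here, amino in place of chloro gives the first step at this place on the ring that passes beyond the scatter (a 2.4-fold higher number from compound 2 to compound 4 (0.39 log units; beyond the scatter)), so this place, para to a large group, does not accept every replacement without a change in the number. The separation is only modest and holds against chloro alone: amino in place of cyano stays within the scatter (a 1.6-fold higher number from compound 3 to compound 4 (0.19 log units; within the scatter)), so compound 3 and compound 4 cannot be told apart here. The change from chloro to amino adds a hydrogen-bond donor and a hydrogen-bond acceptor, but nothing available ties this difference, or any other, to the step.

The compounds shown leave open whether the hydrogens on the amino nitrogen matter to the step, a question that dimethylamino or acetylamino at the same place would address. They also leave open how far the number can move at this place, which a carboxylic acid or a longer chain such as butyl could show.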